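The source may report more compounds than this note shows. Statements on the series, on what has been measured and on what is new or still open speak of the compounds shown alone.

Working notes on the series, measured in a functional assay on HCT-116 cells (Homo sapiens) for antiproliferative activity, read by MTT assay, with a stated time of 72 h; a higher number here means a weaker inhibitor, a lower number a stronger inhibitor:
- compound 1 `C=CC/N=C1\S/C(=C\c2ccc(OC)cc2)C(=O)N1C`: 79300 nM
- compound 2 `COc1ccc(/C=C2\S/C(=N\c3ccc(Cl)cc3)N(C)C2=O)cc1`: 10400 nM
- compound 3 `COc1ccc(/C=C2/CN(C)/C(=N/c3ccc(OC)cc3)S2)cc1`: 15900 nM

Compound 3 cannot be separated from compound 2, as the two values lie within the scatter of each other. Compound 1 carries the higher number, beyond the scatter.

The next compound is compound 4 `COc1ccc(/C=C2/CN(C)/C(=N/c3ccc(Br)cc3)S2)cc1`, which keeps the core of compound 3 and changes one group: bromo in place of methoxy on an aromatic carbon. In words, this is bromo in place of methoxy on an aromatic carbon, or 4-methoxyphenyl to 4-bromophenyl.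

Among the compounds with values here, only one measured step is available, a 7.6-fold lower number from compound 1 to compound 2 (0.88 log units; beyond the scatter). It replaces allyl rather than exchanging one substituent on an aromatic ring for another, so it says little about this change. Compound 2, with its 4-chlorophenyl, gives 10400 nM and compound 3, with its 4-methoxyphenyl, gives 15900 nM. These two also differ elsewhere, so this is only weak support for expecting no large shift. Within the data shown here, no measured pair isolates the exchange itself, and no step beyond the scatter is expected in this assay.

The estimated change is a 1.3-fold lower number from compound 3 to compound 4 (0.12 log units; within the scatter). For compound 4 the expected value is 12000 nM, with an estimated range of 5000 nM to 30000 nM.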

Compound 4, half-maximal inhibitory concentration: 8900 nM
Beside the measured number, compound 4's estimate is 1.3-fold (0.13 log units) above it; the range from low to high includes it.
By their numbers in this assay, from the lowest: compounds 4, 2 and 3 (each within the scatter of the next); then compound 1.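

In this assay, within the data shown here, the exchange of methoxy for bromo gives the first direct reading at this position, a 1.8-fold lower number from compound 3 to compound 4 (0.25 log units; within the scatter) with the rest of the structure held constant, so the two compounds cannot be separated. Among these compounds, on this single pair, an aromatic carbon para to a large group accepts bromo in place of methoxy without a step beyond the scatter, which the earlier compounds could not show because their only measured step replaces allyl on the double-bonded nitrogen. Nothing measured here explains why these two substituents read alike, and no property of either group is available to interpret the result.

As far as these compounds go, one exchange within the scatter does not define the tolerance of this position, so it remains open whether a dimethylamino group, a carboxylic acid or a longer chain such as n-butoxy on the same aromatic carbon would give a step beyond it. The contribution of the carbonyl present in compounds 1 and 2 and absent from compounds 3 and 4 also remains open, as no pair shown differs in that place alone.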